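This account rests on a few compounds, and the source may have more. Where it says the series, first, only, none or still open, it means among the compounds named here.

Measured so far in a functional assay on MDA-MB-435 cells (Homo sapiens) for cytotoxicity, read by sulforhodamine B assay, with a stated time of 48 h, tested at 100 uM; on this read-out higher numbers stand for a weaker effect at the one concentration tested and lower numbers for a stronger effect:

compound 1, `COc1ccc(-c2cc(/C=C/C(=O)c3cc(OC)c(OC)c(OC)c3)[nH]n2)cc1OC`, gives -78%
compound 2, `COc1ccc(C(=O)/C=C/c2cc(-c3cc(OC)c(OC)c(OC)c3)n[nH]2)cc1`, gives -44%
compound 3, `COc1ccc(C(=O)/C=C/c2cc(-c3cc(OC)c(OC)c(OC)c3)n[nH]2)cc1OC`, gives -73%

Among these three numbers compound 3 stands second highest. Its nearest neighbour is compound 1, whose value lies a few points lower, within the scatter, so the two cannot be told apart on this read-out. Among the measured compounds shown here, compound 2 lies further off, and the one single-point step measured, a number 29 percentage points lower from compound 2 to compound 3 (beyond the scatter), is beyond the scatter and of modest size: a methoxy in place of hydrogen on an aromatic carbon lowered the number, meaning a stronger effect at the one concentration tested.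

Compound 4, `COc1cc(C(=O)/C=C/c2cc(-c3cc(OC)c(OC)c(OC)c3)n[nH]2)cc(OC)c1OC`, has not yet been measured. It differs from compound 3 in one place: methoxy in place of hydrogen on an aromatic carbon. For the measured compounds named here, the only measured step that bears on this is the one from compound 2 to compound 3, the same kind of exchange on an aromatic carbon, and it was modest. A second exchange of the same kind need not repeat that size, and compound 3 already sits close to compound 1, so a smaller step in the same direction, or none beyond the scatter, is the more cautious expectation. The estimated step in this assay is a number 7 percentage points lower from compound 3 to compound 4 (within the scatter). Compound 4 is therefore expected to give about -80%, within a range from -100% to -58%.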

Compound 4, a percentage reported as activity, at one concentration (the size of the read-out at that concentration, not a potency): -83%
For compound 4 the middle estimate is 3 percentage points above the measured one, and the stated range covers the measured number.
By their numbers in this assay, from the lowest: compounds 4, 1 and 3 (each within the scatter of the next); then compound 2.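

In this assay, methoxy in place of hydrogen on an aromatic carbon, ortho to a methoxy group, gives a number 10 percentage points lower from compound 3 to compound 4 (within the scatter), so this further exchange cannot be told from no change. The same kind of exchange, reached from the core of compound 1, gives a number 5 percentage points lower from compound 1 to compound 4 (within the scatter), and it too cannot be told from no change. The earlier compounds showed this exchange only as a clear gain, but the new steps show that its size does not carry over from one place to another: the same change on two cores in this assay, a number 29 percentage points lower (beyond the scatter) from compound 2 to compound 3 and a number 5 percentage points lower (within the scatter) from compound 1 to compound 4, 24 percentage points apart, beyond the scatter of two such steps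

The compounds shown leave open whether a hydroxyl, an amine or a longer chain such as ethoxy at this position would shift the number beyond the scatter, or whether methoxy is no different from these groups here. Compound 1, compound 3 and compound 4 cannot be ordered in this assay, and a reading at one concentration does not say how their potencies compare.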